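From Bromine to Nitrile on a Small Fused Core

A few compounds are considered here, and "the series" means these few. Any claim that something is new, unique, unknown or untested is made for them only; others in the source may bear on it.

Of the compounds shown here, three have so far been measured in an assay on isolated protein for inhibition of cytochrome P450 2A6 (Homo sapiens), read by fluorescence, with a stated time of 10 min; a lower number here means a stronger inhibitor, a higher number a weaker inhibitor. Compound 1 `Cc1csc2ccc(Cl)cc12` gives 88000 nM, compound 2 `NCc1csc2ccc(Br)cc12` gives 700 nM, and compound 3 `Brc1cc2ccccc2o1` gives 140000 nM. Compound 3 has the highest number of the three. Its number sits close to that of compound 1, and the gap between them lies within the usual scatter of such measurements, so no order between these two can be claimed. Against compound 2 the gap is far beyond the scatter, and compound 2 clearly inhibits more strongly than compound 3.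

Compound 4 `N#Cc1cc2ccccc2o1` has not yet been measured. It differs from compound 3 in one place: cyano in place of bromo on an aromatic carbon. Going by the values given here, no pair among the measured compounds shows this same change, so no measured step tells how it acts in this assay. The expectation therefore rests only on the size of the change, which is small, and on where compound 3 stands. In this assay compound 4 is expected to give 70000 nM, with a range from 15000 nM to 300000 nM. The step this estimate means, a 2.0-fold lower number from compound 3 to compound 4 (0.30 log units; within the scatter), is expected to be modest, toward a somewhat lower number, and may well stay within the scatter.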

Compound 4, half-maximal inhibitory concentration: 52000 nM
Beside the measured number, compound 4's estimate is 1.3-fold (0.13 log units) above it; the measured number falls inside the stated range.
By their numbers in this assay, from the lowest: compound 2; then compounds 4, 1 and 3 (each within the scatter of the next, the first and the last beyond it).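

Going by these compounds alone, at the aromatic carbon next to the ring oxygen, putting cyano in place of bromo gives a 2.7-fold lower number from compound 3 to compound 4 (0.43 log units; beyond the scatter) in this assay and provides the first direct comparison in this set, since no two earlier compounds differed in only one place. The step shows that the group at this position can shift the number by more than the usual scatter, though only modestly, and that bromo is not needed there to keep the number at the level seen for compound 3. The entering cyano has two heavy atoms and one hydrogen-bond acceptor, whereas the departing bromo has one heavy atom and no hydrogen-bond acceptor, but no measurement shown here says which of these differences, if either, accounts for the step.

A single pair cannot show whether a carboxylic acid, a primary amide or a longer chain on the same carbon would move the number further, or in which direction. On these data alone, it also remains open whether cyano in place of bromo would give a step of similar size on the core of compound 2, where the bromo stands at a different place.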